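This account rests on a few compounds, and the source may have more. Where it says the series, first, only, none or still open, it means among the compounds named here.

Compound 1 `O=S(=O)(/C=C/c1ccccc1)Cc1ccc(Nc2ncnc3ccccc23)cc1`, compound 2 `O=S(=O)(/C=C/c1ccc(Br)cc1)Cc1ccc(Nc2ncnc3ccccc23)cc1` and compound 3 `O=S(=O)(/C=C/c1ccc(Cl)cc1Cl)Cc1ccc(Nc2ncnc3ccccc23)cc1` share one core; compound 4 `O=S(=O)(/C=C/c1ccc(Cl)cc1Cl)Cc1ccc(Nc2ncnc3ccc(Br)cc23)cc1` awaits measurement. In a functional assay on NCI/ADR-RES cells (Homo sapiens) for inhibition (on this read-out lower numbers stand for stronger inhibition of growth and higher numbers for weaker inhibition of growth), compound 1 gives only a limit, > 100000 nM. In this assay compound 2 likewise gives only a limit, > 100000 nM. In this assay compound 3 gives 5000 nM. The change 2,4-dichlorophenyl in place of phenyl on a double-bonded chain carbon bound to a double-bonded chain carbon carries an at least 20-fold lower number from compound 1 to compound 3 (1.30 log units; beyond the scatter), and the same group also carries an at least 20-fold lower number from compound 2 to compound 3 (1.30 log units; beyond the scatter). The change bromo in place of hydrogen on an aromatic carbon yields a step that the two limits leave unreadable from compound 1 to compound 2 because of the limit of > 100000 nM in this assay, at which 2 of the 3 values shown sit. Compound 4 differs from compound 3 by bromo in place of hydrogen on an aromatic carbon, the same kind of change, but here the aromatic ring is part of a fused or bridged system of two rings, meta to a fused ring and para to a fused ring, whereas in compound 2 the position is para to a large group. Set beside a step that the two limits leave unreadable from compound 1 to compound 2, which two limits leave unreadable, only a modest step is expected here, no change at the digits printed from compound 3 to compound 4 (within the scatter), and it rests on nothing firmer than that unreadable precedent. Compound 4 is estimated at 5000 nM, between 1500 nM and 16000 nM.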

Compound 4, concentration for 50% growth inhibition: > 100000 nM
Compound 4 was reported as a limit (the forecaster's own chance of this, stated with the estimate: 10%); at least 20-fold (1.30 log units) between middle value and limit.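

In this assay, bromo in place of hydrogen on an aromatic carbon of the fused system, meta to a fused ring and para to a fused ring, gives an at least 20-fold higher number from compound 3 to compound 4 (1.30 log units; beyond the scatter). The same kind of change para to a large group, from compound 1 to compound 2, cannot be read, so the series does not show whether a bromo effect carries from one core to another. The step to compound 4 gives only a bound, not a full size, because the assay limit is reached: the limit of > 100000 nM in this assay, at which 3 of the 4 values shown sit.

As far as these compounds go, whether an amine or a carboxylic acid at that fused-ring carbon would keep the activity of compound 3, at 5000 nM, remains open. Also open, from the compounds shown here alone, is how bromo at that carbon behaves with a phenyl or 4-bromophenyl group in place of 2,4-dichlorophenyl.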